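The compounds below may be only part of what the source reports. "The series", "measured", "known", "first", "only" and "open" are said of these compounds alone.

Measured compounds:
- Compound 1, `ClCc1ccc(Cn2cnc3c(Cl)ncnc32)cc1`, gives 310 nM
- Compound 2, `ClCc1cccc(Cn2cnc3ncnc(Cl)c32)c1`, gives 1860 nM
- Compound 3, `ClCc1ccc(Cn2cnc3c(Cl)nc(Cl)nc32)cc1`, gives 2340 nM

All three were tested in a functional assay on ACHN cells (Homo sapiens) for cytotoxicity, read by sulforhodamine B assay, with a stated time of 48 h; on this read-out higher numbers stand for weaker inhibition of growth and lower numbers for stronger inhibition of growth. Compound 1 and compound 3 share one core, and compound 3 carries one more chlorine atom than compound 1:

chloro in place of hydrogen on an aromatic carbon

That single change produced a 7.5-fold higher number from compound 1 to compound 3 (0.88 log units; beyond the scatter), so adding the second chloro to this core weakened growth inhibition in this assay. Compound 2 is built from the same atoms as compound 1, joined differently; the difference between the two cores is not broken down here. The values of compound 2 and compound 3 lie within the usual scatter of each other, so no order can be read from them.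

Compound 4, `ClCc1cccc(Cn2cnc3nc(Cl)nc(Cl)c32)c1`, has not yet been measured. It stands to compound 2 as compound 3 stands to compound 1:

chloro in place of hydrogen on an aromatic carbon

The place of the new chloro is described in exactly the same terms as in the earlier pair, so this is the same change on a different core. For the measured compounds named here, the change has been seen only once, which is a thin basis, but it is the only guide available. In this assay the step expected from compound 2 to compound 4 is a 6.5-fold higher number from compound 2 to compound 4 (0.81 log units; beyond the scatter), because the same change gave a 7.5-fold higher number from compound 1 to compound 3 (0.88 log units; beyond the scatter) on the core of compound 1. Compound 4 is therefore estimated to give about 12000 nM in this assay. The expected range for compound 4 runs from 4000 nM to 40000 nM.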

Compound 4, concentration for 50% growth inhibition: 1120 nM
Compound 4: middle estimate off by 11-fold (1.03 log units), on the high side, outside the stated range (below it).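

In this assay, the added chloro did not repeat its earlier effect on the second core: the new step is a 1.7-fold lower number from compound 2 to compound 4 (0.22 log units; within the scatter), which is within the scatter, so on this core the change made no difference that can be read. A change that clearly weakened growth inhibition on the core of compound 1 therefore cannot simply be carried over to the core of compound 2, and the gap between the two steps is larger than repeated measurements would explain: the same change on two cores in this assay, a 7.5-fold higher number (0.88 log units; beyond the scatter) from compound 1 to compound 3 and a 1.7-fold lower number (0.22 log units; within the scatter) from compound 2 to compound 4, 13-fold (1.10 log units) apart, beyond the scatter of two such steps

This shows that, for these two pairs, the result of placing a chloro on the ring carbon between two ring nitrogen atoms depends on the core that carries it, but it does not show why the cores differ, and two pairs give no rule for any further core.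

The compounds shown leave open whether a different group at the same place, such as an amine or a methyl group, would also give different results on the two cores. They also leave open whether the same contrast between the two cores would appear in cell types other than the one tested here.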